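Swapping a Thiazole for an Oxazole on a Shared Core

The source may report more compounds than this note shows. Statements on the series, on what has been measured and on what is new or still open speak of the compounds shown alone.

Measured so far:
compound 1 `c1cc(-c2nccs2)c2c(c1)C(c1ncc[nH]1)CC2`: 426 nM
compound 2 `Cc1n[nH]cc1-c1cccc2c1CCC2c1ncc[nH]1`: 3 nM
compound 3 `c1ccc2c(c1)CCCC2c1ncc[nH]1`: 385 nM

All three compounds were tested in a functional assay on CHO cells for agonist activity at Alpha-1A adrenergic receptor (Homo sapiens), read by FLIPR and calcium flux; a lower number here means that less compound is needed, a higher number that more compound is needed for the effect. Compound 1 gives 426 nM, the highest of the three numbers. Compound 3 lies closest to it, and the gap between the two is within the usual scatter, so nothing separates them. Compound 2 is far away: the change a 140-fold lower number from compound 1 to compound 2 (2.15 log units; beyond the scatter) is the only step shown between compounds that differ in one place.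

Compound 4 `c1cc(-c2ncco2)c2c(c1)C(c1ncc[nH]1)CC2` is not yet measured. It differs from compound 1 in one place: 1,3-oxazol-2-yl in place of 1,3-thiazol-2-yl on an aromatic carbon. The group leaving and the group entering are the same size and carry the same count of donors and acceptors, so this is a small change in kind. Within the data shown here, the one measured step, from compound 1 to compound 2, replaces the same thiazole with a quite different group, one that carries a hydrogen-bond donor, and it cannot be read as a guide for an exchange of one ring atom for another. Among the measured compounds shown here, compound 3 shows only that a related core without this group sits near compound 1.

For the measured compounds named here, with no step of the same kind to lean on, the expectation for compound 4 is a change no larger than the scatter, a 1.2-fold higher number from compound 1 to compound 4 (0.07 log units; within the scatter), and a value around 500 nM, estimated to fall between 150 nM and 1600 nM.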

Compound 4, half-maximal effective concentration: 170 nM
Estimate against measurement, compound 4: 2.9-fold (0.47 log units) above; low and high end bracket the measured number.
By their numbers in this assay, from the lowest: compound 2; then compound 4; then compounds 3 and 1 (each within the scatter of the next).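

The aromatic carbon that carries this ring responds even to a very conservative exchange. In this assay, putting 1,3-oxazol-2-yl in place of 1,3-thiazol-2-yl swaps only sulfur for oxygen in the ring, yet it gives a 2.5-fold lower number from compound 1 to compound 4 (0.40 log units; beyond the scatter) as a modest step that lies beyond the scatter, so the identity of a single ring atom counts here. Even so, this shift is small beside what separates the oxazole from the pyrazole, with a 57-fold higher number from compound 2 to compound 4 (1.75 log units; beyond the scatter) as a large step, so 3-methyl-1H-pyrazol-4-yl remains by far the best of the groups shown at this position, and nothing here accounts for either step.

The compounds shown leave open which feature of 3-methyl-1H-pyrazol-4-yl carries its large effect, and a pyrazole without the methyl group, or an isomeric pyrazole attached through a different ring atom, would help separate the ring from its substituent. On these data alone, it also remains open whether this position accepts groups that are not five-membered aromatic rings at all, such as a simple amine, a carboxylic acid or a short alkyl chain.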